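From compound 3 to compound 4 in the series

This account rests on a few compounds, and the source may have more. Where it says the series, first, only, none or still open, it means among the compounds named here.

Measured in a functional assay on aorta (Rattus norvegicus, strain Sprague-Dawley); a higher number here means that more compound is needed for the effect, a lower number that less compound is needed:
- compound 1 `COC(=O)Nc1c(N)nc(-c2cc3c(C)nn(-c4ccccc4)c3nc2OCc2ccccc2F)nc1N`: 5800 nM
- compound 2 `CCCCOC(=O)Nc1c(N)nc(-c2cc3c(C)nn(-c4ccccc4)c3nc2OCc2ccccc2F)nc1N`: > 100000 nM, a limit
- compound 3 `Cc1nn(-c2ccccc2)c2nc(OCc3ccccc3F)c(-c3nc(N)c(NC(=O)OC4CCCC4)c(N)n3)cc12`: > 100000 nM, a limit

Compound 3 gives no number, only the limit > 100000 nM. It therefore stands at the limit of > 100000 nM in this assay, at which 2 of the 3 values shown sit.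

Compound 4 `Cc1nn(-c2ccccc2)c2nc(OCc3ccccc3F)c(-c3nc(N)c(N4CCOC4=O)c(N)n3)cc12` carries 2-oxo-1,3-oxazolidin-3-yl in place of (cyclopentyloxycarbonyl)amino on an aromatic carbon.

Among the measured compounds shown here, two measured steps bear on this change, and both are large: an at least 17-fold higher number from compound 1 to compound 2 (1.23 log units; beyond the scatter) and an at least 17-fold higher number from compound 1 to compound 3 (1.23 log units; beyond the scatter). The remaining step, a step that the two limits leave unreadable from compound 2 to compound 3, gives no size. Among these compounds, only the methyl on the oxygen next to the carbonyl group gives a number. For the measured compounds named here, no measured compound has the 2-oxo-1,3-oxazolidin-3-yl group, so the two large steps serve only as a loose guide. With the cyclopentyl gone, a move back towards compound 1 at 5800 nM is expected, though only partly. In this assay another limit remains quite possible.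

The expected step is an at least 3.3-fold lower number from compound 3 to compound 4 (0.52 log units; beyond the scatter).

The estimate for compound 4 is 30000 nM, with an expected range from 5000 nM to 100000 nM.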

Compound 4, half-maximal effective concentration: > 100000 nM
Compound 4 gave a limit, no number; the forecaster's own chance of this, stated with the estimate: 45%; middle value at least 3.3-fold (0.52 log units) from the limit.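

In this assay, placing 2-oxo-1,3-oxazolidin-3-yl on this aromatic carbon gives an at least 17-fold higher number from compound 1 to compound 4 (1.23 log units; beyond the scatter). The result for compound 4 is a limit, so a group with a ring containing 2 hetero atoms and 0 hydrogen-bond donors also fails to give a number here: the limit of > 100000 nM in this assay, at which 3 of the 4 values shown sit. Compound 1 therefore remains the only compound shown with a number, and the steps among compounds 2, 3 and 4 cannot be read.

From the compounds shown here alone, how compounds 2, 3 and 4 rank in this assay stays open. Also open, going by these compounds, is whether a plain amine, an acetylamino group or a 2-oxopyrrolidin-1-yl group on this aromatic carbon would give a number.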